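Bromo-to-tert-butyl swap on two dihydrofolate reductase inhibitor cores

A few compounds are considered here, and "the series" means these few. Any claim that something is new, unique, unknown or untested is made for them only; others in the source may bear on it.

The measured compounds:
Compound 1, `CC(C)(C)c1ccc(OCCCON2C(N)=NC(N)=NC23CCSCC3)cc1`, gives 85.3%.
Compound 2, `NC1=NC2(CCSCC2)N(OCCCOc2ccc(Br)cc2)C(N)=N1`, reaches only a limit of the assay, > 90%.
Compound 3, `NC1=NC2(CCOCC2)N(OCCCOc2ccc(Br)cc2)C(N)=N1`, likewise reaches only a limit of the assay, > 90%.

All three were tested in an assay on isolated protein for inhibition of Dihydrofolate reductase (Homo sapiens), read by spectrophotometry, using NADPH, with stated times of 5 s and 6 min, tested at 5 uM; a higher number here means a stronger effect of the compound at the concentration tested, a lower number a weaker effect. The step from compound 2 to compound 1 is a number at least 4.7 percentage points lower from compound 2 to compound 1 (that floor lies within the scatter), the change being (tert-butyl in place of bromo on an aromatic carbon). Its size is hard to pin down because of the limit of > 90% in this assay, at which 2 of the 3 values shown sit. How the core of compound 3 differs from that of compound 2 is not broken down here.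

Compound 4, `CC(C)(C)c1ccc(OCCCON2C(N)=NC(N)=NC23CCOCC3)cc1`, is not yet measured. It differs from compound 3 by tert-butyl in place of bromo on an aromatic carbon, the same change as that from compound 2 to compound 1. The step is expected to be a number at least 5 percentage points lower from compound 3 to compound 4 (that floor lies within the scatter), resting on a number at least 4.7 percentage points lower from compound 2 to compound 1 (that floor lies within the scatter). Compound 4 is therefore estimated at 85% in this assay.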

Compound 4, a percentage reported as inhibition, at one concentration (the size of the read-out at that concentration, not a potency): > 90%
Compound 4: no number, only a limit (the forecaster's own chance of this, stated with the estimate: 25%); at least 5 percentage points between middle value and limit.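

No step can be read from compound 3 to compound 4, as both stand only at a limit in this assay: the limit of > 90% in this assay, at which 3 of the 4 values shown sit.

The compounds shown leave open how far tert-butyl in place of bromo shifts the read-out on the core of compound 3.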